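Acyl swaps on the bis(pyridyl)hydrazone core: next, 4-aminophenyl

This account rests on a few compounds, and the source may have more. Where it says the series, first, only, none or still open, it means among the compounds named here.

Compound 2 `O=C(NN=C(c1ccccn1)c1ccccn1)c1ccncc1` gives 830 nM in an ADME assay on cells (Homo sapiens) for antiproliferative activity, read by MTT assay; a higher number here means a weaker inhibitor, a lower number a stronger inhibitor. Among the two numbers so far it is the lowest, but its only neighbour, compound 1 `O=C(NN=C(c1ccccn1)c1ccccn1)c1cccs1`, stands close: in this assay compound 1 gives 950 nM, and the step of a 1.1-fold lower number from compound 1 to compound 2 (0.06 log units; within the scatter) stays within the scatter, so no order between the two can be claimed.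

Compound 3 `Nc1ccc(C(=O)NN=C(c2ccccn2)c2ccccn2)cc1` is not yet measured. It differs from compound 2 in one place: 4-aminophenyl in place of pyridin-4-yl on a carbonyl carbon. Within the data shown here, the one measured step that bears on this, a 1.1-fold lower number from compound 1 to compound 2 (0.06 log units; within the scatter), also exchanged the aromatic group on that carbonyl carbon and moved the number hardly at all. On that basis the step from compound 2 to compound 3 is expected to stay within the scatter, with no clear direction; the expected size is a 1.0-fold lower number from compound 2 to compound 3 (0.02 log units; within the scatter). For compound 3 the estimate in this assay is 800 nM, with a range from 350 nM to 1900 nM.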

Compound 3, half-maximal inhibitory concentration: 7640 nM
For compound 3 the middle estimate is 9.6-fold (0.98 log units) below the measured one, and the stated range ends below it.
By their numbers in this assay, from the lowest: compounds 2 and 1 (each within the scatter of the next); then compound 3.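

In this assay the aromatic group on the carbonyl carbon turns out not to be freely exchangeable: 4-aminophenyl in place of pyridin-4-yl gives a 9.2-fold higher number from compound 2 to compound 3 (0.96 log units; beyond the scatter), and 4-aminophenyl in place of thiophen-2-yl gives an 8.0-fold higher number from compound 1 to compound 3 (0.91 log units; beyond the scatter), while the earlier exchange gave only a 1.1-fold lower number from compound 1 to compound 2 (0.06 log units; within the scatter). Against pyridin-4-yl, the entering group brings a hydrogen-bond donor and a ring of carbon only, and both changes arrive together in this one step. No measurement on these compounds accounts for the size of the step.

The compounds shown leave open whether the higher number goes with the amine or with the carbon-only ring that carries it; a plain phenyl, or a phenyl bearing a hydroxyl or a methoxy group in place of the amine, would separate the two. Going by these compounds, whether the same step holds on any other core also remains open.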